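Catechol to hydroxybenzyl exchange in a sulfonamide urea series

The source may report more compounds than this note shows. Statements on the series, on what has been measured and on what is new or still open speak of the compounds shown alone.

Measured in an ADME assay on HEK-293T cells (Homo sapiens) for cytotoxicity, read by CCK-8 assay, with a stated time of 48 h; on this read-out lower numbers stand for stronger inhibition and higher numbers for weaker inhibition:
Compound 1 `O=C(NCCNS(=O)(=O)c1ccc(-c2ccccc2Oc2ccc(O)c(O)c2)s1)Nc1cc(Cl)cc(Cl)c1` gives 12400 nM.
Compound 2 `O=C(Nc1cccc([N+](=O)[O-])c1)N1CCN(S(=O)(=O)c2sccc2-c2ccccc2Oc2ccc(O)c(O)c2)CC1` returns only a limit of this assay, > 20000 nM.
Compound 3 `CC(C)c1ccc(Oc2ccc(O)c(O)c2)c(-c2ccsc2S(=O)(=O)NCCNC(=O)Nc2cc(C(F)(F)F)cc(C(F)(F)F)c2)c1` likewise returns only a limit, > 20000 nM.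

Among the compounds with values here, compound 1 holds the only number among the three values shown; the other two sit at the limit of > 20000 nM in this assay, at which 2 of the 3 values shown sit. Compound 4 `O=C(NCCNS(=O)(=O)c1ccc(-c2ccccc2OCc2cccc(O)c2)s1)Nc1cc(Cl)cc(Cl)c1` differs from compound 1 in one place: 3-hydroxybenzyl in place of 3,4-dihydroxyphenyl on an oxygen on an aromatic ring. Within the data shown here, no two measured compounds differ in a single place, so no step size can be read from the data, and what the unmeasured compound will do rests on compound 1 alone. From compound 1 the change is expected to give no step beyond the scatter in this assay, estimated as a 1.2-fold higher number from compound 1 to compound 4 (0.08 log units; within the scatter). Compound 4 is expected near 15000 nM, within 7000 nM to 30000 nM, with a fair chance that this assay reports only a limit.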

Compound 4, half-maximal inhibitory concentration: > 20000 nM
Compound 4 was reported as a limit; the forecaster's own chance of this, stated with the estimate: 40%; at least 1.3-fold (0.12 log units) between middle value and limit.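

Within the data shown here, exchanging 3,4-dihydroxyphenyl for 3-hydroxybenzyl on the oxygen gives the first single-place step at this position in this assay: an at least 1.6-fold higher number from compound 1 to compound 4 (0.20 log units; that floor lies within the scatter). Compound 4 gives a limit and not a number, so this step has a floor only and no upper end. Compound 1 remains the only compound with a number: the limit of > 20000 nM in this assay, at which 3 of the 4 values shown sit.

On these data alone, whether the lost hydroxyl or the inserted carbon matters more stays open, and 3,4-dihydroxybenzyl on the same oxygen would separate the two. As far as these compounds go, whether a benzyl group carrying an amine or a carboxylic acid would give a number in this assay is also open.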